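Removing the piperazine methyl: no change expected in cytotoxicity

The source may hold more compounds than are shown below. What is called first, only, known or untested is meant among the compounds shown, and "the series" means these compounds.

Compound 2 `CN1CCN(c2ccc(/C=C3/SC(N(C)c4ccccc4)=NC3=O)cc2)CC1` was tested in an ADME assay on cells (Homo sapiens) for cytotoxicity, read by sulforhodamine B assay, with a stated time of 48 h; on this read-out higher numbers stand for an effect only at larger amounts of compound and lower numbers for an effect already at smaller amounts. In this assay compound 2 gives only a limit of the assay, > 100000 nM, and not a number. Compound 1 `O=C1N=C(Nc2ccccc2)S/C1=C/c1ccc(N2CCNCC2)cc1`, which also carries an unmethylated ring nitrogen, gives in this assay likewise only a limit, > 100000 nM. Both results sit at the same place, as the limit of > 100000 nM in this assay, at which 2 of the 2 values shown sit, shows, so compound 2 stands exactly where compound 1 stands: no measurable effect within the tested range.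

Compound 3 `CN(C1=NC(=O)/C(=C\c2ccc(N3CCNCC3)cc2)S1)c1ccccc1` differs from compound 2 by hydrogen in place of methyl on an amine nitrogen in a ring, in words hydrogen in place of methyl on an amine nitrogen in a ring. Since compound 1, with the same unmethylated ring, reaches only > 100000 nM, the step that the limit leaves unreadable from compound 2 to compound 3 is expected to be none beyond the scatter. Compound 3 is estimated at 150000 nM, within 80000 nM to 400000 nM, most likely again reported only as a limit.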

Compound 3, half-maximal effective concentration: > 100000 nM
Compound 3: only a limit was reported; the forecaster's own chance of this, stated with the estimate: 85%; the middle value does not contradict the limit.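

Compound 3 gives only a limit of the assay, > 100000 nM. Going by these compounds alone, no step from compound 1 or compound 2 to compound 3 can be read, as all three results rest on one limit: the limit of > 100000 nM in this assay, at which 3 of the 3 values shown sit.

The compounds shown leave open at what amount, if any, they harm the cells, and whether either methyl group changes that amount.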